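The source may hold more compounds than are shown below. What is called first, only, known or untested is meant among the compounds shown, and "the series" means these compounds.

In a functional assay on MIA PaCa-2 cells (Homo sapiens) for cytotoxicity, read by fluorescence, with a stated time of 48 h (on this read-out lower numbers stand for an effect already at smaller amounts and higher numbers for an effect only at larger amounts of compound), compound 1 `CC(C)=CCC/C(C)=C/CC/C(C)=C/CSC[C@H](NC(=O)CCCCCN1CCN(C)CC1)C(=O)NC1CC1` gives 10400 nM. Among the measured compounds shown here, the only other measured compound so far, compound 2 `CC(C)=CCC/C(C)=C/CC/C(C)=C/CSC[C@H](NC(=O)CCCCCN1CCCC1)C(=O)NC1CCCCCC1`, gives 6800 nM. These two numbers lie within the usual scatter of each other, so neither can be ranked ahead of the other.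

Compound 3 `CC(C)=CCC/C(C)=C/CC/C(C)=C/CSC[C@H](NC(=O)CCCCCN1CCN(C)CC1)C(=O)NC1CCCCC1` has not yet been measured. It carries cyclohexyl in place of cyclopropyl on an amide-type nitrogen, and keeps the rest of compound 1: cyclohexyl in place of cyclopropyl on an amide-type nitrogen. For the measured compounds named here, no measured pair differs in this one place, so the data offer no direct guide to the effect of this swap. Going by the values given here, the only hint is that compound 2, at 6800 nM, sits close to compound 1. In this assay, a small step towards a lower number is therefore expected, with none beyond the scatter. The expected change is a 1.4-fold lower number from compound 1 to compound 3 (0.14 log units; within the scatter). For compound 3, the estimated value is 7500 nM, with an expected range from 3500 nM to 16000 nM.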

Compound 3, half-maximal effective concentration: 5900 nM
For compound 3 the middle estimate is 1.3-fold (0.10 log units) above the measured one; low and high end bracket the measured number.
By their numbers in this assay, from the lowest: compounds 3, 2 and 1 (each within the scatter of the next).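

Among the compounds shown here, this is the first pair of compounds that differ in one place only, so the swap of cyclopropyl for cyclohexyl on an amide-type nitrogen can now be read directly. In this assay the swap gives a 1.8-fold lower number from compound 1 to compound 3 (0.25 log units; within the scatter), which lies within the scatter, so going from a three-membered ring of carbon to a six-membered one at this position shows no clear effect on the result. No measurement here offers an explanation for this result.

As far as these compounds go, only these two saturated carbon rings can be compared at this position, so it remains open whether a phenyl or benzyl group, or a small open chain such as methyl, would also stay within the scatter. Compound 2 differs from compound 1 and compound 3 in more than one place, so it gives no separate reading of the amine at the end of the chain.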